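Swapping chloro for nitro in compound 3

The source may hold more compounds than are shown below. What is called first, only, known or untested is meant among the compounds shown, and "the series" means these compounds.

Measured in a functional assay on RS4-11 cells (Homo sapiens) for inhibition, read by CCK-8 assay, with a stated time of 48 h; on this read-out higher numbers stand for weaker inhibition and lower numbers for stronger inhibition:
compound 1 `O=S(=O)(NCCNC(=S)Nc1cccc(Cl)c1)c1ccc(-c2ccccc2OCc2cccc(O)c2)s1`: 5800 nM
compound 2 `COc1ccc(Oc2ccc(C(C)C)cc2-c2ccsc2S(=O)(=O)NCCNC(=O)Nc2cc(Cl)cc(Cl)c2)cc1OC`: 9000 nM
compound 3 `O=S(=O)(NCCNC(=S)Nc1cccc(Cl)c1)c1ccc(-c2ccccc2OCc2ccccc2)s1`: > 50000 nM (a limit, not a number)

Compound 3 sits on (the limit of > 50000 nM in this assay, at which 1 of the 3 values shown sits). Only a limit is known for it, so no exact position can be given in this assay.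

Compound 4 `O=[N+]([O-])c1cccc(NC(=S)NCCNS(=O)(=O)c2ccc(-c3ccccc3OCc3ccccc3)s2)c1` is made from compound 3 by one change, nitro in place of chloro on an aromatic carbon. The ring carrying this group is otherwise untouched.

For the measured compounds named here, no measured step covers this swap. Going by the values given here, the only measured step is an at least 8.6-fold higher number from compound 1 to compound 3 (0.93 log units; beyond the scatter), where hydrogen replaces hydroxy on an aromatic carbon. That step lies elsewhere in the molecule, and compound 4 has hydrogen at that place, as compound 3 does. Compound 2 differs from the others in more than one place, so it offers no clean comparison.

With no hydroxy restored, compound 4 is expected to remain weak, close to the limit, with no clear direction of change. The expected step is an at least 1.2-fold lower number from compound 3 to compound 4 (0.09 log units; that floor lies within the scatter). Compound 4 is estimated at 40000 nM, with an expected range from 12000 nM to 80000 nM.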

Compound 4, half-maximal inhibitory concentration: 11600 nM
Compound 4: the middle estimate sits 3.4-fold (0.54 log units) above what was measured; measured number below the stated range.
By their numbers in this assay, from the lowest: compounds 1, 2 and 4 (each within the scatter of the next). At a limit, above all of these: compound 3.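

In this assay, the change from 3-chlorophenyl to 3-nitrophenyl gives an at least 4.3-fold lower number from compound 3 to compound 4 (0.63 log units; beyond the scatter). For the compounds shown here, the earlier compounds showed a clear effect only at the hydroxy place, on the other side of the molecule, so this is the first sign that the group on this second ring also matters, and that a compound without the hydroxy can still give a measurable value, as compound 4 does with 11600 nM. The exact size of the step cannot be given because compound 3 has only a limit, not a number: the limit of > 50000 nM in this assay, at which 1 of the 4 values shown sits.

On these data alone, it remains open whether this gain depends on nitro itself or would also appear with another group at the same place, such as an amine or a carboxylic acid, and the two values here cannot show why nitro does better than chloro. As far as these compounds go, it is also open whether the hydroxy and the nitro would add up if both were present in one molecule, which would show whether the two places act independently.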